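Chloro to methoxy on the shared core, cytotoxicity in view

A few compounds are considered here, and "the series" means these few. Any claim that something is new, unique, unknown or untested is made for them only; others in the source may bear on it.

Compound 1 `O=C1CSC(c2cccc(Cl)c2)N1CCN1CCCCC1` sits alongside compound 2 `O=C1CSC(c2ccc(O)cc2)N1CCN1CCCCC1` and compound 3 `O=C1CSC(c2ccc(F)cc2)N1CCN1CCCCC1`, which differ from it only in the group carried on a saturated ring carbon of the shared core. In an ADME assay on Vero cells (Chlorocebus sabaeus) for cytotoxicity, read by neutral red uptake, tested at 25 ug/mL (on this read-out higher numbers stand for a weaker effect at the one concentration tested and lower numbers for a stronger effect), compound 1 gives 100%, compound 2 gives 100% and compound 3 gives 100%, so compound 1 stands level with both. The unmeasured compound 4 `COc1cccc(C2SCC(=O)N2CCN2CCCCC2)c1` differs from compound 1 by methoxy in place of chloro on an aromatic carbon. The measured steps that bear on this change are no change at the digits printed from compound 1 to compound 2 (within the scatter) and no change at the digits printed from compound 1 to compound 3 (within the scatter), each a swap of the same group, and neither moved the read-out. A further swap of this kind is therefore expected to leave the read-out unchanged, so compound 4 is estimated at 100% within 85% to 100%, meaning an expected step of no change at the digits printed from compound 1 to compound 4 (within the scatter).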

Compound 4, a percentage reported as activity, at one concentration (the size of the read-out at that concentration, not a potency): 97%
Estimate against measurement, compound 4: 3 percentage points above; the measured number falls inside the stated range.
By their numbers in this assay, from the lowest: compounds 4, 1, 2 and 3 (each within the scatter of the next).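

In this assay methoxy in place of chloro on an aromatic carbon, meta to a large group, gives a number 3 percentage points lower from compound 1 to compound 4 (within the scatter) and so shows that this place can hold a group of two heavy atoms with a hydrogen-bond acceptor and stay within the scatter. The earlier compounds shown here did not show this, since none carried methoxy here. Nothing measured here gives a reason for this result. Still open, going by these compounds, is whether an amine, a carboxylic acid or a longer chain at this same place would also stay level with compound 1.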